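The source may hold more compounds than are shown below. What is called first, only, known or untested is meant among the compounds shown, and "the series" means these compounds.

Series notes, hydroxyphenyl positional pair.

Compound 1 `Oc1ccc(-c2cc(-c3ccco3)cc(-c3cccc(O)c3)n2)cc1` and compound 2 `Oc1ccc(-c2cc(-c3ccco3)cc(-c3ccc(O)cc3)n2)cc1` share one core; compound 3 `Oc1cccc(-c2cc(-c3ccccn3)cc(-c3ccccc3O)n2)c1` stands on a different core, and the difference between the two cores is not broken down here. In an assay on isolated protein for inhibition of DNA topoisomerase 1 (Homo sapiens), with a stated time of 30 min, tested at 100 uM (a higher number here means a stronger effect of the compound at the concentration tested, a lower number a weaker effect), compound 1 gives 100%. Compound 2 gives 100% in this assay. Compound 3 gives 35.4% in this assay, the lowest of the three numbers, and its distance from compound 1 and from compound 2 lies beyond the scatter.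

The change from compound 1 to compound 2 is 4-hydroxyphenyl in place of 3-hydroxyphenyl on an aromatic carbon. Its effect was no change at the digits printed from compound 1 to compound 2 (within the scatter).

Compound 4 `Oc1ccc(-c2cc(-c3ccccn3)cc(-c3ccccc3O)n2)cc1` has not been measured. The change from compound 3 to compound 4 is 4-hydroxyphenyl in place of 3-hydroxyphenyl on an aromatic carbon. Within the data shown here, this is the same kind of change as the one from compound 1 to compound 2, not the same change: in compound 3 the place is meta to a 2-hydroxyphenyl group and meta to a pyridin-2-yl group, whereas in compound 1 it is meta to a 4-hydroxyphenyl group and meta to a furan-2-yl group. Among the measured compounds shown here, only one earlier example of this kind of change exists here, and it sits where both values are at the top of the read-out, so it cannot show whether the change moves the number at all.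

The step from compound 3 to compound 4 in this assay is expected to be a number 2.6 percentage points higher from compound 3 to compound 4 (within the scatter), resting on the earlier step of no change at the digits printed from compound 1 to compound 2 (within the scatter) being flat. Compound 4 is estimated at 38% in this assay, with the range 15% to 65%.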

Compound 4, a percentage reported as inhibition, at one concentration (the size of the read-out at that concentration, not a potency): 0.2%
Beside the measured number, compound 4's estimate is 37.8 percentage points above it; the whole stated range lies above it.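

In this assay, 4-hydroxyphenyl in place of 3-hydroxyphenyl gives a number 35.2 percentage points lower from compound 3 to compound 4 (beyond the scatter), so the flat result on the first core did not carry over to the second: the same change on two cores in this assay, no change at the digits printed (within the scatter) from compound 1 to compound 2 and a number 35.2 percentage points lower (beyond the scatter) from compound 3 to compound 4, 35.2 percentage points apart, beyond the scatter of two such steps

This does not show that the change acts differently on the two cores in any underlying sense, since the earlier step sits at the top of the read-out, with compound 1 at 100% and compound 2 at 100%, where a loss from the change could stay hidden. Nor do two steps show which difference between the cores matters, as the core of compound 1 and the core of compound 3 differ in more than one place, among them furan-2-yl against pyridin-2-yl and 4-hydroxyphenyl against 2-hydroxyphenyl at the remaining position.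

Still open, as far as these compounds go, is whether the step follows the pyridin-2-yl group or the 2-hydroxyphenyl group, which a pair carrying only one of the two would settle, ideally at concentrations where the read-out stays off its top. Also open, from the compounds shown here alone, is whether the position of the hydroxyl matters in the same way when an amine or a methoxy group stands in its place.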